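A few compounds are considered here, and "the series" means these few. Any claim that something is new, unique, unknown or untested is made for them only; others in the source may bear on it.

The two compounds whose values are in hand share one core. Compound 1, `CC1CCCCC1N(CCCCCCN1C[C@H](O)[C@@H](O)[C@H](O)[C@H]1CO)C(=O)OC(C)(C)C`, gives in an ADME assay on BHK cells (Mesocricetus auratus) for cytotoxicity, read by MTT assay (a higher number here means that more compound is tolerated, a lower number that less compound is tolerated), a value of 230000 nM. Compound 2, `CC(C)(C)C(=O)N(CCCCCCN1C[C@H](O)[C@@H](O)[C@H](O)[C@H]1CO)C1CCCCC1`, reaches only the limit of this assay, > 500000 nM, so for compound 2 no number but a limit is known. That is the situation described by the limit of > 500000 nM in this assay, at which 1 of the 2 values shown sits, and it means that compound 2 sits at the edge of what this assay can report, while compound 1 lies within the measured range.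

Compound 3, `CC(C)(C)C(=O)N(CCCCCCN1C[C@H](O)[C@@H](O)[C@H](O)[C@H]1CO)C1CCC1`, differs from compound 2 in one place: cyclobutyl in place of cyclohexyl on an amide-type nitrogen. Among the measured compounds shown here, no measured pair in this set shows what such an exchange does in this assay, so the expectation for compound 3 rests on the two values alone. Given that compound 2 already sits at the limit, the step from compound 2 to compound 3 is expected to be a number no higher from compound 2 to compound 3 (the limit leaves the size open), with a change beyond the scatter considered unlikely. Compound 3 is accordingly expected to give about 500000 nM in this assay, within a range from 200000 nM to 1000000 nM, and a further limit-only reading is thought likely.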

Compound 3, half-maximal cytotoxic concentration: > 500000 nM
Compound 3: a limit, no number (the forecaster's own chance of this, stated with the estimate: 55%); the middle value lies on the limit itself.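

Compound 2 and compound 3 both reach only a limit in this assay, so the exchange of cyclohexyl for cyclobutyl between them gives no step that can be read: the limit of > 500000 nM in this assay, at which 2 of the 3 values shown sit.

The compounds shown leave open where the true values of compound 2 and compound 3 lie, and whether cyclobutyl in place of cyclohexyl on an amide-type nitrogen changes tolerance at all.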